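A few compounds are considered here, and "the series" means these few. Any claim that something is new, unique, unknown or untested is made for them only; others in the source may bear on it.

Compound 1 `C=CCOc1cc(C2=C(c3cc(OC)c(OC)c(OC)c3)C(=O)C(O)C2)ccc1OC` shares its core with the other compounds described here. In an ADME assay on L132 cells (Homo sapiens) for cytotoxicity, read by MTT assay, with a stated time of 72 h (a lower number here means a stronger inhibitor, a higher number a weaker inhibitor), compound 1 gives > 100 ug/mL, which is a limit of the assay rather than a number. Compound 2 `COc1ccc(C2=C(c3cc(OC)c(OC)c(OC)c3)C(=O)C(OC(C)=O)C2)cc1` gives in this assay > 100 ug/mL, again a limit. Compound 3 `COc1ccc(C2=C(c3cc(OC)c(OC)c(OC)c3)C(=O)C(OC(C)=O)C2)cc1OC(C)C` carries an isopropoxy in place of hydrogen on an aromatic carbon relative to compound 2. In this assay compound 3 gives > 100 ug/mL, also a limit. The step that the two limits leave unreadable from compound 2 to compound 3 therefore cannot be sized, and compound 3 stands on a limit together with the two other values, as the limit of > 100 ug/mL in this assay, at which 3 of the 3 values shown sit, shows.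

Compound 4 `COc1ccc(C2=C(c3cc(OC)c(OC)c(OC)c3)C(=O)C(O)C2)cc1OC(C)C` differs from compound 3 by hydrogen in place of acetyl on an oxygen on a saturated carbon. No measured step among these compounds bears on this change, since every value sits at the limit. Compound 4 is therefore expected to behave like the three measured compounds, with a step that the limit leaves unreadable from compound 3 to compound 4 no larger than the scatter. For compound 4 the estimate in this assay is 150 ug/mL, with a range from 80 ug/mL to 400 ug/mL, most likely reported again as a limit.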

Compound 4, half-maximal inhibitory concentration: > 100 ug/mL
Compound 4: only a limit was reported (the forecaster's own chance of this, stated with the estimate: 85%); the middle value is on the limit's open side.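

In this assay, among these compounds, neither the step from compound 3 to compound 4 nor the one from compound 1 to compound 4 can be read: all three compounds stand on a limit. The compounds shown leave open where each true half-maximal inhibitory concentration lies, and whether either change shifts it at all.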